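Toxicity Notes on a Coumarin-Indole Hydrazone Series

The source may hold more compounds than are shown below. What is called first, only, known or untested is meant among the compounds shown, and "the series" means these compounds.

The series shares one core, a coumarin-bearing indole carrying an acylhydrazone, and differs at the acyl aryl group and at one aromatic carbon of the coumarin. Compound 1 `O=C(N/N=C/c1c(-c2cc3ccccc3oc2=O)[nH]c2ccccc12)c1ccc(Cl)cc1` carries a 4-chlorophenyl on the carbonyl carbon. In a toxicity assay on Vero cells (Chlorocebus sabaeus) for inhibition, read by MTT assay, with a stated time of 48 h (a higher number here means a weaker inhibitor, a lower number a stronger inhibitor), compound 1 gives > 200000 nM, which is a limit of the assay and not a number. Compound 2 `O=C(N/N=C/c1c(-c2cc3ccccc3oc2=O)[nH]c2ccccc12)c1ccccc1Cl` differs from compound 1 by 2-chlorophenyl in place of 4-chlorophenyl on a carbonyl carbon. In this assay compound 2 gives > 200000 nM, again a limit. The step that the two limits leave unreadable from compound 1 to compound 2 therefore cannot be sized, since the limit of > 200000 nM in this assay, at which 2 of the 3 values shown sit, holds both values. Compound 3 `O=C(N/N=C/c1c(-c2cc3ccc(Br)cc3oc2=O)[nH]c2ccccc12)c1ccc(Cl)cc1` differs from compound 1 by bromo in place of hydrogen on an aromatic carbon. In this assay, among the measured compounds shown here, compound 3 gives 71400 nM, the only true number in the set. For the measured compounds named here, the step of an at least 2.8-fold lower number from compound 1 to compound 3 (0.44 log units; beyond the scatter) is the one readable change so far.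

Compound 4 `O=C(N/N=C/c1c(-c2cc3ccc(Br)cc3oc2=O)[nH]c2ccccc12)c1ccccc1Cl` differs from compound 3 by 2-chlorophenyl in place of 4-chlorophenyl on a carbonyl carbon, the same change as from compound 1 to compound 2, made on the brominated core. The earlier instance of this change gave no readable step because a step that the two limits leave unreadable from compound 1 to compound 2 sits between two limits. With only that to rest on, the expected step from compound 3 to compound 4 is small, a 1.3-fold higher number from compound 3 to compound 4 (0.10 log units; within the scatter), and compound 4 is estimated in this assay at 90000 nM, with a range from 30000 nM to 200000 nM. A limit rather than a number remains a real possibility for compound 4.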

Compound 4, half-maximal inhibitory concentration: 89300 nM
The estimate for compound 4 lay 1.0-fold (0.00 log units) above the measured number; the measured number falls inside the stated range.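

In this assay, 2-chlorophenyl in place of 4-chlorophenyl on a carbonyl carbon gives a 1.3-fold higher number from compound 3 to compound 4 (0.10 log units; within the scatter) on the brominated core, while the same change on the core of compound 1 cannot be read, so these compounds do not show whether its small size carries over from one core to the other. Bromo in place of hydrogen on an aromatic carbon gives an at least 2.2-fold lower number from compound 2 to compound 4 (0.35 log units; beyond the scatter), so the change runs in the same direction with the 2-chlorophenyl group as with the 4-chlorophenyl group, and its size is known only as a lower bound on both cores: the same change on two cores in this assay, an at least 2.8-fold lower number (0.44 log units; beyond the scatter) from compound 1 to compound 3 and an at least 2.2-fold lower number (0.35 log units; beyond the scatter) from compound 2 to compound 4; the limit leaves it open whether they differ The true size of the bromo step on either core therefore stays unknown, and a match between the two steps is not shown, because both non-brominated compounds rest at a limit: the limit of > 200000 nM in this assay, at which 2 of the 4 values shown sit.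

From the compounds shown here alone, what a carboxylic acid or an amine in place of the chlorine on the acyl phenyl ring would give in this assay remains open. Also open, going by these compounds, is whether fluoro or methoxy in place of the bromo would give a step like the one seen with bromo.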